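Hydrogen in Place of Fluorine on Two Related Cores

This account rests on a few compounds, and the source may have more. Where it says the series, first, only, none or still open, it means among the compounds named here.

Compound 1 `COc1ccc(C2=NN(C(=O)c3ccc4c(c3)OCCO4)C(c3ccc(F)cc3)C2)cc1` and compound 4 `COc1ccc(C2=NN(C(=O)c3ccc4c(c3)OCCO4)C(c3ccccc3)C2)cc1` share one core, while compound 2 `O=C(C1COc2ccccc2O1)N1N=C(c2ccc(Br)cc2)CC1c1ccccc1F` and compound 3 `O=C(C1COc2ccccc2O1)N1N=C(c2ccc(Br)cc2)CC1c1ccccc1` share another; the difference between the two cores is not broken down here. In a functional assay on WM 266-4 cells (Homo sapiens) for inhibition, read by MTT assay, with a stated time of 24 h (a higher number here means a weaker inhibitor of growth, a lower number a stronger inhibitor of growth), compound 1 gives 3780 nM, compound 2 gives 8030 nM and compound 3 gives 6150 nM. Compound 3 arises from compound 2 by hydrogen in place of fluoro on an aromatic carbon and this step made a 1.3-fold lower number from compound 2 to compound 3 (0.12 log units; within the scatter). Compound 4 has not yet been measured; it arises from compound 1 by hydrogen in place of fluoro on an aromatic carbon. The two changes are the same kind of change, not the same: in compound 2 the fluoro sits ortho to a large group, whereas in compound 1 it sits para to a large group. Among the compounds with values here, only one measured example of this change exists, and it stayed within the scatter. In this assay the expected step is a 1.2-fold lower number from compound 1 to compound 4 (0.07 log units; within the scatter), resting on the measured step of a 1.3-fold lower number from compound 2 to compound 3 (0.12 log units; within the scatter). Compound 4 is therefore expected to give 3200 nM. The expected range for compound 4 runs from 1500 nM to 7000 nM.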

Compound 4, concentration for 50% growth inhibition: 2370 nM
Beside the measured number, compound 4's estimate is 1.4-fold (0.13 log units) above it; low and high end bracket the measured number.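

In this assay, putting hydrogen in place of fluoro, which turns 4-fluorophenyl into phenyl, made a 1.6-fold lower number from compound 1 to compound 4 (0.20 log units; within the scatter). Set beside the earlier case on the other core, the two steps agree: the same change on two cores in this assay, a 1.3-fold lower number (0.12 log units; within the scatter) from compound 2 to compound 3 and a 1.6-fold lower number (0.20 log units; within the scatter) from compound 1 to compound 4, 1.2-fold (0.09 log units) apart, within the scatter of two such steps. This shows that, in these two pairs, the change behaves alike on both cores; it does not show that removing fluoro improves growth inhibition, since each step is small enough to be ordinary scatter between repeated measurements, and two pairs cannot establish a rule for the whole series.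

Still open, from the compounds shown here alone, is whether a different group in place of the fluoro, such as an amine or a carboxylic acid, would shift the number by more than the scatter. No pair shown isolates the difference between the two cores either, so how each part of that difference affects growth inhibition remains unknown.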